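Replacing an aminomethyl isoxazole substituent with a small amide

The source may hold more compounds than are shown below. What is called first, only, known or untested is meant among the compounds shown, and "the series" means these compounds.

The series shares the core seen in compound 3 `C=CNCc1cc(-c2c(C(=O)NCC)noc2-c2cc(C(C)C)c(O)cc2O)on1`, in which a resorcinol bearing an isopropyl group is joined to an oxazole carrying an ethylamide and a second five-membered ring. Among the measured compounds shown here, in a functional assay on A2780 cells (Homo sapiens) for inhibition (on this read-out lower numbers stand for stronger inhibition and higher numbers for weaker inhibition), compound 3 gives 43 nM, and this is the only number the set offers. For compound 1 `CCNC(=O)c1noc(-c2cc(C(C)C)c(O)cc2O)c1-c1cc(COCC(=O)O)no1` the entry in this assay reads "not determined" (no result reported). For compound 2 `CCNC(=O)c1noc(-c2cc(C(C)C)c(O)cc2O)c1-c1cc(CN)no1` the entry in this assay likewise reads "not determined" (no result reported), so compound 3 cannot be ranked against anything here. Compound 4 `CCNC(=O)c1noc(-c2cc(C(C)C)c(O)cc2O)c1-c1cc(C(=O)NC)no1` differs from compound 3 in one place: methylcarbamoyl in place of (vinylamino)methyl on an aromatic carbon. For the measured compounds named here, with no measured pair of neighbouring compounds available, the size of the step can only be judged from the single value of compound 3 and the nature of the swap. The author expects the amide to cost some potency, and estimates the step of a 1.9-fold higher number from compound 3 to compound 4 (0.27 log units; within the scatter) to lie at the edge of the usual scatter, in the direction of weaker inhibition. Compound 4 is therefore estimated at 80 nM, with a plausible range from 20 nM to 400 nM.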

Compound 4, half-maximal inhibitory concentration: 100 nM
Estimate against measurement, compound 4: 1.3-fold (0.10 log units) below; the range from low to high includes it.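

The first measured pair shows that this carbon, next to the ring nitrogen, can carry either of two quite different side chains with activity retained. In this assay, replacing (vinylamino)methyl with methylcarbamoyl gives a 2.3-fold higher number from compound 3 to compound 4 (0.37 log units; beyond the scatter), a modest loss, and compound 4 still reaches 100 nM. The two groups match in heavy atoms, hydrogen-bond donors and hydrogen-bond acceptors, so these counts alone do not keep the two compounds level, and nothing shown here accounts for the difference.

As far as these compounds go, it remains open how a carboxylic acid, a dimethylamino group or a longer ethylcarbamoyl chain on this carbon would read in this assay. A single pair also gives no indication of whether the step would keep its size and direction with other groups elsewhere on the shared core.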